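A few compounds are considered here, and "the series" means these few. Any claim that something is new, unique, unknown or untested is made for them only; others in the source may bear on it.

Compound 1 `CCNC(=O)c1cc(Oc2ccc(NC(=O)c3cc4cccnc4n(-c4ccc(F)cc4)c3=O)cc2)ccn1` gives 120 nM in a functional assay on A549 cells (Homo sapiens) for antiproliferative activity, read by MTT assay, with a stated time of 72 h (a lower number here means a stronger inhibitor, a higher number a weaker inhibitor), the lower of the two numbers in hand. Among the compounds with values here, the only other measured compound, compound 2 `CCNC(=O)c1cc(Oc2ccc(NC(=O)c3cc4cccnc4n(-c4ccc(Br)cc4)c3=O)cc2)ccn1`, gives 910 nM in this assay, and the step of a 7.6-fold higher number from compound 1 to compound 2 (0.88 log units; beyond the scatter) came from bromo in place of fluoro on an aromatic carbon. Compound 3 `CCCNC(=O)c1cc(Oc2ccc(NC(=O)c3cc4cccnc4n(-c4ccc(F)cc4)c3=O)cc2)ccn1` differs from compound 1 by methyl in place of hydrogen on a saturated chain carbon, two bonds along the chain from an amide-type nitrogen. That one measured step touches a different part of the shared core, so nothing in hand bears on this change. Compound 3 is therefore expected to give 130 nM, between 50 nM and 350 nM. The expected step is a 1.1-fold higher number from compound 1 to compound 3 (0.03 log units; within the scatter), nothing beyond the scatter.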

Compound 3, half-maximal inhibitory concentration: 62 nM
For compound 3 the middle estimate is 2.1-fold (0.32 log units) above the measured one, within the range that was stated.
By their numbers in this assay, from the lowest: compounds 3 and 1 (each within the scatter of the next); then compound 2.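

In this assay, methyl in place of hydrogen on this saturated chain carbon, which turns ethylamino into propylamino, gives a step within the scatter (a 1.9-fold lower number from compound 1 to compound 3 (0.29 log units; within the scatter)). Within the data shown here, the first reading at this position therefore shows that the added methyl leaves the number within the scatter of compound 1, so the position accepts propyl here. No measurement in hand offers an explanation for this result. Still open, as far as these compounds go, is whether a longer chain such as butyl, or a terminal amine on the chain, would also stay within the scatter.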